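A few compounds are considered here, and "the series" means these few. Any claim that something is new, unique, unknown or untested is made for them only; others in the source may bear on it.

Working notes on the series.

The shared core is varied at two places: the group on the carbonyl carbon and the group on the aromatic carbon ortho to the large group. Compound 1 `CC(=O)Nc1ccc(S(=O)(=O)Oc2ccccc2C(C)C)cc1` is measured in a functional assay on MCF7 cells (Homo sapiens) for antiproliferative activity, read by sulforhodamine B assay, with a stated time of 48 h (on this read-out higher numbers stand for weaker inhibition and lower numbers for stronger inhibition), and compound 1 gives 16000 nM. Compound 2 `CC(=O)Nc1ccc(S(=O)(=O)Oc2ccccc2I)cc1` differs from compound 1 by iodo in place of isopropyl on an aromatic carbon; in this assay compound 2 gives 27000 nM, and the step is a 1.7-fold higher number from compound 1 to compound 2 (0.23 log units; within the scatter). Compound 3 `CCCNC(=O)Nc1ccc(S(=O)(=O)Oc2ccccc2C(C)C)cc1` carries the second core, which differs from the core of compound 1 by propylamino in place of methyl on a carbonyl carbon; in this assay compound 3 gives 2700 nM, the step being a 5.9-fold lower number from compound 1 to compound 3 (0.77 log units; beyond the scatter). Among the three measured compounds, compound 3 holds the lowest number, with its steps to both others beyond the scatter.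

Compound 4 `CCCNC(=O)Nc1ccc(S(=O)(=O)Oc2ccccc2I)cc1` is not yet measured. It differs from compound 3 by iodo in place of isopropyl on an aromatic carbon. This is the same change as that from compound 1 to compound 2, with the place described in identical words, now made on the core of compound 3 rather than the core of compound 1. On the first core that change gave a 1.7-fold higher number from compound 1 to compound 2 (0.23 log units; within the scatter). Among the compounds with values here, the step from compound 3 to compound 4 is expected to be a 1.7-fold higher number from compound 3 to compound 4 (0.23 log units; within the scatter), because the only measured instance of the change gave a 1.7-fold higher number from compound 1 to compound 2 (0.23 log units; within the scatter). On these data alone, whether the change carries over unaltered to the second core is untested; one pair alone speaks to it, so the range is kept wide. Compound 4 is expected at 4600 nM, between 2000 nM and 11000 nM.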

Compound 4, half-maximal inhibitory concentration: 2900 nM
Estimate against measurement, compound 4: 1.6-fold (0.20 log units) above, and the stated range covers the measured number.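

In this assay, iodo in place of isopropyl on an aromatic carbon now gives a 1.1-fold higher number from compound 3 to compound 4 (0.03 log units; within the scatter), and this change carries from one core to the other without a measurable difference: the same change on two cores in this assay, a 1.7-fold higher number (0.23 log units; within the scatter) from compound 1 to compound 2 and a 1.1-fold higher number (0.03 log units; within the scatter) from compound 3 to compound 4, 1.6-fold (0.20 log units) apart, within the scatter of two such steps

Propylamino in place of methyl on a carbonyl carbon gives a 9.3-fold lower number from compound 2 to compound 4 (0.97 log units; beyond the scatter), so the lower number seen with this change also persists with iodo in place of isopropyl: the same change on two cores in this assay, a 5.9-fold lower number (0.77 log units; beyond the scatter) from compound 1 to compound 3 and a 9.3-fold lower number (0.97 log units; beyond the scatter) from compound 2 to compound 4, 1.6-fold (0.20 log units) apart, within the scatter of two such steps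

Across these four compounds the two changes therefore combine without any sign of dependence on each other, but this rests on one square of compounds in one assay; it does not show that either change would carry to other cores, and it gives no explanation for the size of either step.

The compounds shown leave open whether the step seen with propylamino extends to a longer chain or a cyclic amine on the carbonyl carbon, and whether a methoxy group or a plain hydrogen on the aromatic carbon would fit the same picture. They also leave open whether the same independence of the two changes would appear in any other read-out.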